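The source may hold more compounds than are shown below. What is called first, only, known or untested is meant among the compounds shown, and "the series" means these compounds.

Of the compounds shown here, two of a shared core have been measured in a functional assay on HCC827 cells (Homo sapiens) for antiproliferative activity, read by MTT assay, with a stated time of 72 h; a lower number here means a stronger inhibitor, a higher number a weaker inhibitor. Compound 1 `CN1CCN(c2ccc(Nc3ncc4nc(Nc5ccc(F)cc5)n(-c5cccc(NC(=O)CO)c5)c4n3)cc2)CC1` gives 7.5 nM, the lowest of the two numbers. Compound 2 `CN1CCN(c2ccc(Nc3ncc4nc(Nc5ccccc5)n([C@H]5CCN(S(C)(=O)=O)C5)c4n3)cc2)CC1` gives 17 nM, a gap from compound 1 that lies beyond the usual scatter of repeated measurements. Compound 3 `CN1CCN(c2ccc(Nc3ncc4nc(Nc5ccc(F)cc5)n([C@@H]5CCN(C(=O)OC(C)(C)C)C5)c4n3)cc2)CC1` has not yet been measured. It differs from compound 1 in one place: 1-(tert-butoxycarbonyl)pyrrolidin-3-yl in place of 3-(((hydroxymethyl)carbonyl)amino)phenyl on an aromatic nitrogen. Compound 2 also carries a substituted pyrrolidinyl group on that aromatic nitrogen in place of a phenyl ring, and its value is the higher of the two measured. On that basis the step of a 2.0-fold higher number from compound 1 to compound 3 (0.30 log units; within the scatter) is expected to be small and towards a higher number, though it may fall within the scatter. Compound 3 is therefore estimated at 15 nM, with a likely range from 5 nM to 50 nM in this assay.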

Compound 3, half-maximal inhibitory concentration: 27 nM
The estimate for compound 3 lay 1.8-fold (0.26 log units) below the measured number; the range from low to high includes it.
By their numbers in this assay, from the lowest: compound 1; then compounds 2 and 3 (each within the scatter of the next).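

In this assay, this aromatic nitrogen of the shared core still carries a compound with a low number when a non-aromatic ring replaces the aromatic one: putting 1-(tert-butoxycarbonyl)pyrrolidin-3-yl in place of 3-(((hydroxymethyl)carbonyl)amino)phenyl gives a 3.6-fold higher number from compound 1 to compound 3 (0.56 log units; beyond the scatter), leaving compound 3 at 27 nM. Compound 2 could not show this, as it differs from compound 1 in more than this one place. The entering group has no hydrogen-bond donors and a different ring, so this single step cannot separate those two changes, and no measurement here explains its size.

Open, on these data alone, is how this assay would read with a free amine on the pyrrolidine ring nitrogen in place of the tert-butoxycarbonyl group. Also open, as far as these compounds go, is whether the mirror-image pyrrolidine would give a different number.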